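The source may hold more compounds than are shown below. What is called first, only, known or untested is meant among the compounds shown, and "the series" means these compounds.

In a functional assay on HepG2 cells (Homo sapiens) for antiproliferative activity, read by MTT assay, with a stated time of 72 h (a lower number here means a stronger inhibitor, a higher number a weaker inhibitor), compound 3 `CCN(CC)CCCn1cccc1/C=N/NC(=O)Nc1ccc(Oc2ccnc3[nH]ccc23)c(F)c1` gives 2140 nM. Compound 1 `COc1ccc(/C=N/NC(=O)Nc2ccc(Oc3ccnc4[nH]ccc34)cc2)c(OC)c1OC` gives 2960 nM, and these two values lie within the usual scatter of each other. Compound 2 `CN(C)CCn1cccc1/C=N/NC(=O)Nc1ccc(Oc2ccnc3[nH]ccc23)c(F)c1` gives 8980 nM.

Compound 4 `O=C(N/N=C/c1cccn1CCCN1CCCCC1)Nc1ccc(Oc2ccnc3[nH]ccc23)c(F)c1` differs from compound 3 at a single place: piperidin-1-yl in place of diethylamino on a saturated chain carbon, three bonds along the chain from an aromatic nitrogen. In plain terms, piperidin-1-yl stands in place of diethylamino on a saturated chain carbon, three bonds along the chain from an aromatic nitrogen.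

Among the measured compounds shown here, only one measured step bears on this end of the chain: a 4.2-fold lower number from compound 2 to compound 3 (0.62 log units; beyond the scatter). It was a modest step, with (diethylamino)methyl in place of dimethylamino. For the measured compounds named here, no measured compound carries piperidin-1-yl, so the data offer no direct comparison. The new group is only slightly larger than the one it replaces, so a smaller change than that modest step seems likely, and no clear direction can be assigned. In this assay, the expected result is a 1.1-fold higher number from compound 3 to compound 4 (0.05 log units; within the scatter), which would be no real shift beyond the scatter. The estimated value for compound 4 is 2400 nM, with an expected range from 1000 nM to 6000 nM.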

Compound 4, half-maximal inhibitory concentration: 2840 nM
The estimate for compound 4 lay 1.2-fold (0.07 log units) below the measured number, and the stated range covers the measured number.
By their numbers in this assay, from the lowest: compounds 3, 4 and 1 (each within the scatter of the next); then compound 2.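

In this assay, replacing the open diethylamino group with the ring of piperidin-1-yl, at the same place on the chain, gives a 1.3-fold higher number from compound 3 to compound 4 (0.12 log units; within the scatter) and so no real shift. This position therefore accepts both a ring and an open amine end group, at least for these two groups. Compound 4 also keeps a clear gap from the shorter dimethylamino compound, with a 3.2-fold lower number from compound 2 to compound 4 (0.50 log units; beyond the scatter), much as the diethylamino compound did. Nothing measured here explains why the two end groups read alike.

Compound 2 differs from the other two in both chain length and end group, so a 3-(dimethylamino)propyl chain would be needed to tell those two changes apart. Also open, on these data alone, is how a morpholine ring or a smaller pyrrolidine ring would behave at the end of the chain.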